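The source may report more compounds than this note shows. Statements on the series, on what has been measured and on what is new or still open speak of the compounds shown alone.

Compound 1 `CCCc1cc(NC2CCC2)c2cc(NC(=O)/C=C/c3ccc(C(F)(F)F)cc3)ccc2n1` gives 270 nM in a functional assay on HEK293 cells for activation of melanin-concentrating hormone receptor 1 (Homo sapiens), read by inositol phosphate accumulation; a lower number here means that less compound is needed, a higher number that more compound is needed for the effect.
Compound 2 `Nc1cc(C2CCC2)nc2ccc(NC(=O)/C=C/c3ccc(C(F)(F)F)cc3)cc12` gives 250 nM in this assay.
Compound 3 `CCCc1cc(N)c2cc(NC(=O)C3CCC(c4ccc(Cl)cc4)CC3)ccc2n1` gives 370 nM in this assay.

Compound 2 has the lowest of these three numbers, but its distance to compound 1 and to compound 3 lies within the usual scatter, so on these data the three compounds cannot be told apart. Compound 4 `Nc1cc(-c2ccccc2)nc2ccc(NC(=O)/C=C/c3ccc(C(F)(F)F)cc3)cc12` has not been measured yet. It differs from compound 2 in one place: phenyl in place of cyclobutyl on an aromatic carbon. For the measured compounds named here, no measured pair differs in a single place only, so no step of known size is available to lean on. Compound 1 and compound 3 carry a propyl group where compound 2 carries cyclobutyl, and compound 3 also has a different amide part, yet all three give similar numbers, which hints that variation here has so far produced only small changes. A small step is therefore expected, most likely none beyond the scatter, with a slight rise being somewhat more likely than a fall. Compound 4 is expected to give about 350 nM, with a likely range from 90 nM to 1400 nM. This estimate corresponds to an expected step of a 1.4-fold higher number from compound 2 to compound 4 (0.15 log units; within the scatter).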

Compound 4, half-maximal effective concentration: 6600 nM
The estimate for compound 4 lay 19-fold (1.28 log units) below the measured number; the whole stated range lies below it.
By their numbers in this assay, from the lowest: compounds 2, 1 and 3 (each within the scatter of the next); then compound 4.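

Replacing cyclobutyl with phenyl on the aromatic carbon next to the ring nitrogen gives a 26-fold higher number from compound 2 to compound 4 (1.42 log units; beyond the scatter) in this assay, which shows that this position is sensitive to the group it carries. The earlier compounds shown here could not show this, as no two of them differ in one place only. The change swaps a four-membered non-aromatic ring for a six-membered aromatic ring, and nothing available here explains why the number rises.

As far as these compounds go, it remains open whether ring size or aromatic character matters more, and cyclohexyl would separate the two: a number close to that of compound 2 would point to aromatic character, and one close to that of compound 4 to ring size. How a small group such as methyl or a pyridyl ring would fare at this position is also unknown.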